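Fluoro for hydrogen across a small series: cytotoxicity notes

A few compounds are considered here, and "the series" means these few. Any claim that something is new, unique, unknown or untested is made for them only; others in the source may bear on it.

Measured so far in an ADME assay on L6 cells (Rattus norvegicus) for cytotoxicity, read by resazurin assay, with a stated time of 72 h; a lower number here means a stronger inhibitor, a higher number a weaker inhibitor:
compound 1 `OC(c1ccc(Cl)cc1)(c1cccnc1)c1ccc(Cl)cc1F` gives 59400 nM
compound 2 `NC(=O)c1cccc(C(O)(c2ccc(Cl)cc2)c2cccnc2)c1` gives > 100000 nM, a limit of the assay
compound 3 `NC(=O)c1cccc(C(O)(c2cccnc2)c2ccc(Cl)cc2F)c1` gives > 100000 nM, a limit of the assay

Within the data shown here, compound 1 gives the only number; the other two values are limits, and the limit of > 100000 nM in this assay, at which 2 of the 3 values shown sit, covers compound 2 and compound 3. Among the measured compounds shown here, the one measured change, (fluoro in place of hydrogen on an aromatic carbon), yields a step that the two limits leave unreadable from compound 2 to compound 3. How the core of compound 1 differs from that of compound 2 is not broken down here.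

Compound 4 `OC(c1cccnc1)(c1ccc(Cl)cc1F)c1ccc(Cl)cc1F` is not yet measured. It stands to compound 1 as compound 3 stands to compound 2, the same change: fluoro in place of hydrogen on an aromatic carbon. In this assay a step of a 1.2-fold lower number from compound 1 to compound 4 (0.07 log units; within the scatter) is expected. That expectation rests on compound 1 alone, with 59400 nM, as the measured step from compound 2 to compound 3 gives no readable size. Compound 4 is therefore estimated at 50000 nM, within 20000 nM to 120000 nM.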

Compound 4, half-maximal inhibitory concentration: 56300 nM
Compound 4: middle estimate off by 1.1-fold (0.05 log units), on the low side; the range from low to high includes it.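

In this assay, fluoro in place of hydrogen gives a 1.1-fold lower number from compound 1 to compound 4 (0.02 log units; within the scatter), so on the core of compound 1, going from 4-chlorophenyl to 4-chloro-2-fluorophenyl leaves the two compounds indistinguishable. The same replacement on the core of compound 2 cannot be read, since compound 2 and compound 3 both sit at a limit, not a number: the limit of > 100000 nM in this assay, at which 2 of the 4 values shown sit. Whether the result carries from one core to another is therefore not shown, as only one readable step exists, on one core.

Still open, from the compounds shown here alone, is how this assay reads with an amine or a carboxylic acid in place of the amide on the core of compound 2. A longer chain there is equally untested in the compounds shown.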